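Ester in place of the tert-butyl amide on the shared core

The source may hold more compounds than are shown below. What is called first, only, known or untested is meant among the compounds shown, and "the series" means these compounds.

Working notes on a small set sharing one core. Compound 1 `CC1CCN(C(=O)c2c(N)sc(-c3ccc(Cl)cc3)c2-c2ccc(Cl)cc2)CC1` is measured in a functional assay on A549 cells (Homo sapiens) for inhibition, read by sulforhodamine B assay, with a stated time of 72 h (a lower number here means a stronger inhibitor, a higher number a weaker inhibitor), and compound 1 gives 1750 nM. Compound 2 `CC(C)(C)NC(=O)c1c(N)sc(-c2ccc(Cl)cc2)c1-c1ccc(Cl)cc1` gives 8850 nM in this assay. Among the measured compounds shown here, on these two numbers compound 2 stands as the higher one, and the only step so far, a 5.1-fold higher number from compound 1 to compound 2 (0.70 log units; beyond the scatter), lies beyond the scatter.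

The next compound, compound 3 `COC(=O)c1c(N)sc(-c2ccc(Cl)cc2)c1-c1ccc(Cl)cc1`, is not yet measured. It differs from compound 2 as follows: methoxy in place of (tert-butyl)amino on a carbonyl carbon. For the measured compounds named here, no measured step bears directly on this change; the one step known, a 5.1-fold higher number from compound 1 to compound 2 (0.70 log units; beyond the scatter), concerns a different exchange on the same carbonyl carbon and shows only that the group on that carbon can move the number by a modest amount. There is no basis for a direction, so a step of that order in either direction is possible, with none beyond the scatter equally plausible.

On this footing compound 3 is expected to give about 10000 nM in this assay, within 3000 nM to 35000 nM, which is estimated as a 1.1-fold higher number from compound 2 to compound 3 (0.05 log units; within the scatter).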

Compound 3, half-maximal inhibitory concentration: 5040 nM
Compound 3: middle estimate off by 2.0-fold (0.30 log units), on the high side; the measured number falls inside the stated range.
By their numbers in this assay, from the lowest: compound 1; then compounds 3 and 2 (each within the scatter of the next).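

In this assay the exchange of (tert-butyl)amino for methoxy on the carbonyl carbon gives a 1.8-fold lower number from compound 2 to compound 3 (0.24 log units; within the scatter), so among these compounds the ester and the tert-butyl amide cannot be told apart, although methoxy is the smaller group and lacks the hydrogen-bond donor of (tert-butyl)amino. Set against the 4-methylpiperidin-1-yl amide, the same ester gives a 2.9-fold higher number from compound 1 to compound 3 (0.46 log units; beyond the scatter), so compound 1 keeps the lowest number of the three, with its steps to both other compounds beyond the scatter, and this position now reads as one where the 4-methylpiperidin-1-yl group stands apart while the two other groups do not separate. No measurement at hand accounts for these differences.

Open, on these data alone, is whether a carboxylic acid or an unsubstituted primary amide on this carbonyl carbon would fall with compounds 2 and 3 or nearer compound 1. Equally open, as far as these compounds go, is whether the lower number of compound 1 belongs to the 4-methylpiperidin-1-yl group in particular, which a plain piperidin-1-yl or a morpholin-4-yl amide would help to settle.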